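A Second Methyl on the Aryl Amide of Compound 2

The source may report more compounds than this note shows. Statements on the series, on what has been measured and on what is new or still open speak of the compounds shown alone.

Of the compounds shown here, three sharing one core have been tested in an assay on NIH3T3 cells with Urotensin-2 receptor (Homo sapiens) as the target; a higher number here means a larger maximal response, a lower number a smaller maximal response. Compound 1 `CN(C)CCC(OC(=O)c1ccc2ccccc2c1)c1ccc(Cl)cc1` gives 49%. Compound 2 `Cc1ccccc1C(=O)NC(CCN(C)C)c1ccc(Cl)cc1` gives 175%, the highest of the three numbers. Compound 3 `CN(C)CCC(NC(=O)c1ccc(C(F)(F)F)cc1)c1ccc(Cl)cc1` gives 115%, which lies below compound 2 by a margin beyond the scatter, while compound 1 lies still further below it, also beyond the scatter. No pair among these three differs in only one place, so no single step between measured compounds is available to guide the next one.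

Compound 4 `Cc1cccc(C(=O)NC(CCN(C)C)c2ccc(Cl)cc2)c1C` has not yet been measured in this assay. Relative to compound 2 it differs as follows: methyl in place of hydrogen on an aromatic carbon. Cut one bond further out, the change reads 2-methylphenyl to 2,3-dimethylphenyl.

With nothing measured on this kind of change, the expectation rests on compound 2 alone, whose 175% is the top of the series. The step expected in this assay from compound 2 to compound 4 is therefore a modest decrease or none beyond the scatter, a number 25 percentage points lower from compound 2 to compound 4 (beyond the scatter). Compound 4 is expected to give 150%, estimated between 100% and 200%.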

Compound 4, largest response reached (reported as efficacy), in percent of the reference or control that the assay uses: 159%
Beside the measured number, compound 4's estimate is 9 percentage points below it; the range from low to high includes it.
By their numbers in this assay, from the lowest: compound 1; then compound 3; then compound 4; then compound 2.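

In this assay, placing a methyl on the aromatic carbon ortho to a methyl group and meta to a large group, which turns 2-methylphenyl into 2,3-dimethylphenyl, gives a number 16 percentage points lower from compound 2 to compound 4 (beyond the scatter). Within the data shown here, this is the first step that changes one place only, so it gives the first direct reading of a single change on the aryl amide. Compound 2 gives 175% and compound 4 gives 159%, so the second methyl lowers the maximal response at this position but leaves it large, and nothing available accounts for the size of this step.

Going by these compounds, whether an ethyl group, a methoxy group or an amine on this same aromatic carbon would lower the maximal response further, match the methyl or restore the number of compound 2 stays open. On these data alone, it also remains open how a methyl on this carbon would act on a ring without the first methyl, and so whether this step depends on the 2-methylphenyl group already present.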